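Capping a Phenol: What to Expect in Cell Growth

The compounds below may be only part of what the source reports. "The series", "measured", "known", "first", "only" and "open" are said of these compounds alone.

Of the compounds shown here, two sharing one core have been tested in a functional assay on SF-539 cells (Homo sapiens) for inhibition, read by sulforhodamine B assay, with a stated time of 48 h, tested at 1 uM; on this read-out lower numbers stand for a stronger effect and higher numbers for a weaker effect at the one concentration tested. Compound 1 `O=C(Nc1cccc(-n2cc(-c3ccncc3)c(-c3cc(O)cc(Cl)c3)n2)c1)Nc1ccc(Cl)c(C(F)(F)F)c1` gives 91% in this assay, the highest of the two numbers and thus the weaker effect. Compound 2 `O=C(Nc1cccc(-n2cc(-c3ccncc3)c(-c3cc(O)cc(Cl)c3)n2)c1)Nc1ccc(Cl)c(Cl)c1` gives 72%. Among the measured compounds shown here, the only measured step, a number 19 percentage points lower from compound 1 to compound 2 (beyond the scatter), involves chloro in place of trifluoromethyl on an aromatic carbon, a different part of the molecule from the change considered here.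

Compound 3 `COc1cc(Cl)cc(-c2nn(-c3cccc(NC(=O)Nc4ccc(Cl)c(C(F)(F)F)c4)c3)cc2-c2ccncc2)c1` differs from compound 1 by methyl in place of hydrogen on an oxygen on an aromatic ring, that is, hydroxy to methoxy. For the measured compounds named here, no measured step touches this oxygen, so the single recorded step offers no guide to direction or size. Without precedent, the step of a number 3 percentage points lower from compound 1 to compound 3 (within the scatter) is expected to stay within the usual scatter. Compound 3 is therefore estimated at 88%, with an expected range from 68% to 102%.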

Compound 3, a percentage reported as activity, at one concentration (the size of the read-out at that concentration, not a potency): 75%
Estimate against measurement, compound 3: 13 percentage points above; measured number inside the range.
By their numbers in this assay, from the lowest: compounds 2 and 3 (each within the scatter of the next); then compound 1.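

Capping this oxygen does change the read-out: in this assay, going from hydroxy to methoxy gives a number 16 percentage points lower from compound 1 to compound 3 (beyond the scatter), which means a stronger effect at the one concentration tested. So the hydrogen on this oxygen is not needed for the effect in these cells, and this position responds to a change even as small as one added methyl. Nothing available here explains the shift.

The compounds shown leave open how a longer chain, such as ethoxy, or an amine in place of the hydroxy would read at this position. They also leave open whether the same change from hydroxy to methoxy would give a similar step on compound 2, which carries chloro in place of trifluoromethyl.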